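This account rests on a few compounds, and the source may have more. Where it says the series, first, only, none or still open, it means among the compounds named here.

Compound 1 `COc1cccc(CNCCCNc2ccnc3cc(Oc4ccc(Cl)cc4)ccc23)c1O` is the point of departure. In an ADME assay for permeability, using PAMPA, with a stated time of 30 min, at pH 7.4 (a higher number here means that the compound crosses the layer faster, a lower number that the compound crosses the layer more slowly), compound 1 gives 317 10^-6 cm/s. Two related compounds sit alongside it: compound 2 `COc1ccc(F)cc1CNCCCNc1ccnc2cc(-c3cccc4ccccc34)ccc12` gives 237 10^-6 cm/s and compound 3 `CC(C)(C)c1ccc(-c2ccc3c(NCCCNCc4ccco4)ccnc3c2)cc1` gives 237 10^-6 cm/s, and all three numbers lie within the usual scatter of one another, so no order can be read among them. Compound 4 `COc1cccc(CNCCCNc2ccnc3cc(CC(C)C)ccc23)c1O` has not yet been measured. It differs from compound 1 in one place: isobutyl in place of 4-chlorophenoxy on an aromatic carbon. Among the measured compounds shown here, no step between measured compounds covers this change, so the expectation rests on compound 1 alone and its value of 317 10^-6 cm/s. Compound 4 is expected to show no step beyond the scatter, the expected step being a 1.3-fold lower number from compound 1 to compound 4 (0.10 log units; within the scatter). Compound 4 is estimated at 250 10^-6 cm/s, with a range from 130 10^-6 cm/s to 450 10^-6 cm/s.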

Compound 4, apparent permeability: 23 10^-6 cm/s
For compound 4 the middle estimate is 11-fold (1.04 log units) above the measured one; the whole stated range lies above it.
By their numbers in this assay, from the lowest: compound 4; then compounds 2, 3 and 1 (each within the scatter of the next).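

In this assay, among the compounds shown here, isobutyl in place of 4-chlorophenoxy on this aromatic carbon gives a 14-fold lower number from compound 1 to compound 4 (1.14 log units; beyond the scatter) and so shows that the group here can matter greatly, which the earlier compounds, all within the scatter of one another, could not show. The group that leaves carries a six-membered aromatic ring of carbon only and a hydrogen-bond acceptor, and isobutyl carries neither. Nothing measured here bears on why the number falls. Which part of 4-chlorophenoxy matters remains open. Unsubstituted phenoxy or a longer alkyl chain at this place would help to separate them.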